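A pyridin-3-yl swap on compound 3

This account rests on a few compounds, and the source may have more. Where it says the series, first, only, none or still open, it means among the compounds named here.

In an ADME assay (liver) for metabolic stability, with Liver microsome (Homo sapiens) as the target, using microsomes and NADPH, with a stated time of 30 min, tested at 1 uM (on this read-out higher numbers stand for fast clearance and lower numbers for slow clearance), compound 1 `Cn1cc(-c2cc(C(O)(C(F)(F)F)C(F)(F)F)cnc2N2CCN(S(=O)(=O)c3ccc(N)nc3)CC2)cn1` gives 19 mL.min-1.g-1 and compound 2 `NC(=O)c1cccc(-c2cc(C(O)(C(F)(F)F)C(F)(F)F)cnc2N2CCN(S(=O)(=O)c3ccc(N)nc3)CC2)c1` gives 17 mL.min-1.g-1 while compound 3 `CS(=O)(=O)c1ccc(-c2cc(C(O)(C(F)(F)F)C(F)(F)F)cnc2N2CCN(S(=O)(=O)c3ccc(N)nc3)CC2)cc1` gives 32 mL.min-1.g-1 on the same read-out. These numbers lie within the usual scatter of one another, so compound 3 does not stand apart from the other two. Compound 4 `Nc1ccc(S(=O)(=O)N2CCN(c3ncc(C(O)(C(F)(F)F)C(F)(F)F)cc3-c3cccnc3)CC2)cn1` differs from compound 3 by one swap pyridin-3-yl in place of 4-(methylsulfonyl)phenyl on an aromatic carbon that puts pyridin-3-yl in place of 4-(methylsulfonyl)phenyl on an aromatic carbon. Three swaps at this same place bear on it: the steps of a 1.7-fold higher number from compound 1 to compound 3 (0.23 log units; within the scatter) and a 1.9-fold higher number from compound 2 to compound 3 (0.27 log units; within the scatter) and a 1.1-fold lower number from compound 1 to compound 2 (0.05 log units; within the scatter) all stay small, so no step beyond the scatter is expected in this assay here. An expected 1.5-fold lower number from compound 3 to compound 4 (0.16 log units; within the scatter) would stay inside that scatter. Compound 4 is estimated at 22 mL.min-1.g-1 with a range from 10 mL.min-1.g-1 to 45 mL.min-1.g-1 in this measurement.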

Compound 4, intrinsic clearance in microsomes: 17 mL.min-1.g-1
Estimate against measurement, compound 4: 1.3-fold (0.11 log units) above, within the range that was stated.
By their numbers in this assay, from the lowest: compounds 2, 4, 1 and 3 (each within the scatter of the next).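

Pyridin-3-yl, which carries fewer heavy atoms than 4-(methylsulfonyl)phenyl, stays within the scatter of each earlier group at this place: there is a 1.9-fold lower number from compound 3 to compound 4 (0.27 log units; within the scatter) and no change at the digits printed from compound 2 to compound 4 (within the scatter) and a 1.1-fold lower number from compound 1 to compound 4 (0.05 log units; within the scatter). Across these four compounds, then, a plain six-membered aromatic ring with one nitrogen does not stand apart from the larger sulfone and amide groups in this assay. Nothing shown accounts for this flat result. As far as these compounds go, it remains open whether a group of another kind at this place, such as an amine, a carboxylic acid or a longer alkyl chain, would also stay within the scatter.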